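A few compounds are considered here, and "the series" means these few. Any claim that something is new, unique, unknown or untested is made for them only; others in the source may bear on it.

Measured compounds:
Compound 1 `CCCn1nccc1-c1ccccc1NCC1=NCCN1`, 59%
Compound 2 `CC(C)n1nccc1-c1ccccc1NCC1=NCCN1`, 0%
Compound 3 `Cn1ncnc1-c1ccccc1NCC1=NCCN1`, 91%

In a functional assay with Alpha-1A adrenergic receptor (Homo sapiens) as the target, read by calcium flux (on this read-out lower numbers stand for smaller maximal responses and higher numbers for larger maximal responses), compound 2 stands lowest of the three: compound 1 sits nearer, compound 3 furthest, both higher than compound 2 beyond the scatter. Compound 4 `CCn1nccc1-c1ccccc1NCC1=NCCN1` differs from compound 2 by hydrogen in place of methyl on a saturated chain carbon bound to an aromatic nitrogen and a saturated chain carbon. For the measured compounds named here, the one measured step that bears on this is a number 59 percentage points lower from compound 1 to compound 2 (beyond the scatter), where a branched group entered in place of a straight chain and the maximal response fell sharply. Going by the values given here, compound 4 goes back to a straight chain, shorter than in compound 1, so a large rise from compound 2 is expected in this assay, though how far remains open with only this one step. Compound 4 is therefore estimated at 55%, between 20% and 90%, meaning an expected step of a number 55 percentage points higher from compound 2 to compound 4 (beyond the scatter).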

Compound 4, largest response reached (reported as maximal response), in percent of the reference or control that the assay uses: 81%
The estimate for compound 4 lay 26 percentage points below the measured number; low and high end bracket the measured number.
By their numbers in this assay, from the lowest: compound 2; then compound 1; then compounds 4 and 3 (each within the scatter of the next).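

In this assay, the step of a number 81 percentage points higher from compound 2 to compound 4 (beyond the scatter) shows that the collapse seen with isopropyl is not a general feature of this aromatic nitrogen position, since ethyl, with one methyl fewer, restores a high maximal response. Chain length along the straight series also counts, though less: a number 22 percentage points higher from compound 1 to compound 4 (beyond the scatter). Nothing shown explains either step.

On these data alone, whether a butyl or a cyclopropyl group on this nitrogen would keep the response or lose it stays open. So does the effect of a hydroxyl or an amine on the ethyl chain.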